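This account rests on a few compounds, and the source may have more. Where it says the series, first, only, none or still open, it means among the compounds named here.

Compound 2 `CNC(=O)c1cccn(Cc2ccccc2)c1=O`: 78 ug/mL
Compound 1 `CNC(=O)c1cc(C(=O)NC2CC2)cn(Cc2cccc(OC)c2)c1=O`: 79 ug/mL

In a physicochemical assay for solubility (on this read-out lower numbers stand for lower solubility and higher numbers for higher solubility), compound 2 gives 78 ug/mL, the lower of the two numbers, while compound 1 gives 79 ug/mL, which lies within the scatter of the value for compound 2. Compound 3 `CNC(=O)c1cc(C(=O)NCCOC)cn(Cc2ccccc2)c1=O` has not yet been measured in this assay. It differs from compound 2 by (2-methoxyethyl)carbamoyl in place of hydrogen on an aromatic carbon. Within the data shown here, no measured pair tracks this change, and compound 1, which also carries a carbamoyl group, gives 79 ug/mL, close to compound 2; the expected step is therefore a 1.0-fold higher number from compound 2 to compound 3 (0.01 log units; within the scatter), none beyond the scatter. Compound 3 is estimated at 80 ug/mL, between 35 ug/mL and 180 ug/mL.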

Compound 3, solubility: >= 164 ug/mL
Compound 3 ended at the assay's limit (the forecaster's own chance of this, stated with the estimate: 5%); middle value at least 2.0-fold (0.31 log units) away from the limit.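

Replacing hydrogen with (2-methoxyethyl)carbamoyl on the aromatic carbon two atoms from the ring nitrogen gives an at least 2.1-fold higher number from compound 2 to compound 3 (0.32 log units; beyond the scatter) in this assay and is the first single change shown at this position. Among these compounds, it shows that a change at this place can move the read-out beyond the scatter, which no earlier pair could show.

As far as these compounds go, whether an amine, a carboxylic acid or a longer chain at this position would move the read-out in the same way stays open. The value of compound 3 is a limit of the assay, so the full size of the step also stays open: the limit of >= 164 ug/mL in this assay, at which 1 of the 3 values shown sits.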